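The source may report more compounds than this note shows. Statements on the series, on what has been measured and on what is new or still open speak of the compounds shown alone.

Working notes on the series. Compound 2 `NC(=S)N/N=C/c1ccc2ccccc2n1` stands at the high end of the numbers seen so far: in a functional assay on HT-29 cells (Homo sapiens) for antiproliferative activity, read by sulforhodamine B assay, with a stated time of 72 h (a lower number here means a stronger inhibitor, a higher number a weaker inhibitor), compound 2 gives 100000 nM. Compound 1 `NC(=S)N/N=C/c1cc2ccccc2s1` gives 99200 nM in this assay, which sits within the scatter of compound 2. Compound 3 `CN(C)C(=S)N/N=C/c1cnc2ccccc2n1` gives 450 nM in this assay, a number far below compound 2 and well beyond the scatter. Compound 4 `S=C(N/N=C/c1ccc2ccccc2n1)Nc1ccccc1` has not yet been measured in this assay. Compound 4 differs from compound 2 by phenyl in place of hydrogen on an amide-type nitrogen. Within the data shown here, no measured pair shows this change on its own. Compound 4 is expected to give a lower number than compound 2 in this assay, with an estimated step of a 20-fold lower number from compound 2 to compound 4 (1.30 log units; beyond the scatter). The estimate for compound 4 in this assay is 5000 nM, in a range from 800 nM to 30000 nM.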

Compound 4, half-maximal inhibitory concentration: 17000 nM
Beside the measured number, compound 4's estimate is 3.4-fold (0.53 log units) below it; measured number inside the range.
By their numbers in this assay, from the lowest: compound 3; then compound 4; then compounds 1 and 2 (each within the scatter of the next).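

The amide-type nitrogen on the thiocarbonyl carbon accepts a substituent without loss of activity: in this assay, phenyl in place of hydrogen gives a 5.9-fold lower number from compound 2 to compound 4 (0.77 log units; beyond the scatter) as the first single change measured in the series. No measured data on the cause of this step are available.

A methyl or benzyl group on this nitrogen would show whether the gain needs the aromatic ring directly attached. As far as these compounds go, whether phenyl gives a similar step on the core of compound 1 also stays open.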